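Hydrazone variation on a shared nucleoside core: aryl for alkyl

The source may hold more compounds than are shown below. What is called first, only, known or untested is meant among the compounds shown, and "the series" means these compounds.

Compound 1 `Nc1nc(N/N=C/c2ccc(N(c3ccccc3)c3ccccc3)cc2)nc2c1ncn2[C@@H]1O[C@H](CO)[C@@H](O)[C@H]1O`, compound 2 `CSCC/C=N/Nc1nc(N)c2ncn([C@@H]3O[C@H](CO)[C@@H](O)[C@H]3O)c2n1` and compound 3 `Nc1nc(N/N=C/c2ccc(OCc3ccccc3)c(OCc3ccccc3)c2)nc2c1ncn2[C@@H]1O[C@H](CO)[C@@H](O)[C@H]1O` share one core and differ only in the hydrazone substituent. In an assay on CHO-K1 cells for displacement of a labelled ligand from adenosine receptor A1 (Homo sapiens), read by scintillation counting, with a stated time of 60 min, tested at 1 uM (a higher number here means more inhibition at the concentration tested (going by the name of the read-out), a lower number less inhibition), compound 1 gives 0%, compound 2 gives 0% and compound 3 gives 0%. Compound 2 thus stands level with both others at the digits shown, within the scatter, and no ordering among the three can be drawn.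

Compound 4 `CN(C)c1ccc(/C=N/Nc2nc(N)c3ncn([C@@H]4O[C@H](CO)[C@@H](O)[C@H]4O)c3n2)cc1` is the next member. Its change from compound 2: 4-(dimethylamino)phenyl in place of 2-(methylsulfanyl)ethyl on a carbon with a double bond to nitrogen. Compound 1 and compound 3 also carry ring-bearing groups instead of a chain; compound 1 gives 0% and compound 3 gives 0% in this assay. The step is therefore expected to be none beyond the scatter, a number 2 percentage points higher from compound 2 to compound 4 (within the scatter). Compound 4 is expected to give 2%, with a range from -8% to 14%.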

Compound 4, a percentage reported as inhibition, at one concentration (the size of the read-out at that concentration, not a potency): 0%
Compound 4: middle estimate off by 2 percentage points, on the high side, and the stated range covers the measured number.
By their numbers in this assay, from the lowest: compounds 1, 2, 3 and 4 (each within the scatter of the next).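

In this assay, 4-(dimethylamino)phenyl in place of 2-(methylsulfanyl)ethyl on a carbon with a double bond to nitrogen gives no change at the digits printed from compound 2 to compound 4 (within the scatter). With this swap of a chain for an aromatic ring, the position gives no readable response at the concentration tested, and with compound 2 already at 0%, the step could not have shown a loss. Nothing on hand accounts for this result.

Still open, going by these compounds, is whether a carboxylic acid on the phenyl ring or a longer alkyl chain at this position would give a reading beyond the scatter.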